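Fluoro-to-hydrogen step on the biaryl across two urea cores

A few compounds are considered here, and "the series" means these few. Any claim that something is new, unique, unknown or untested is made for them only; others in the source may bear on it.

Compound 1 `Cc1ccc(CN2CCC(NC(=O)NCc3ccc(-c4ccc(F)cc4)cc3)CC2)cc1` and compound 2 `Cc1ccc(CN2CCC(NC(=O)NCc3ccc(-c4ccccc4)cc3)CC2)cc1` share one urea core; in an in vitro functional assay on HEK293 cells for antagonist activity at melanin-concentrating hormone receptor 1 (Homo sapiens), read by GTPgammaS binding, with a stated time of 45 min (on this read-out lower numbers stand for lower potency and higher numbers for higher potency (the scale is a negative logarithm)), compound 1 gives 6.71 and compound 2 gives 5.98. The change between them is hydrogen in place of fluoro on an aromatic carbon, and the step is a number 0.73 log units lower from compound 1 to compound 2 (beyond the scatter). Compound 3 `CCC(CO)(CO)NC(=O)N(CCC1CCN(Cc2ccc(C)cc2)CC1)Cc1ccc(-c2ccc(F)cc2)cc1` carries a different core; the difference between the two cores is not broken down here. In this assay compound 3 gives 6.54, which lies within the scatter of compound 1 and beyond it relative to compound 2. Compound 4 `CCC(CO)(CO)NC(=O)N(CCC1CCN(Cc2ccc(C)cc2)CC1)Cc1ccc(-c2ccccc2)cc1` is compound 3 with the same change, (hydrogen in place of fluoro on an aromatic carbon), at the same place. Because the measured step of a number 0.73 log units lower from compound 1 to compound 2 (beyond the scatter) was modest and clear, a similar loss is expected here. Compound 4 is expected to give 5.9 in this assay, between 5.5 and 6.4, a step of a number 0.64 log units lower from compound 3 to compound 4 (beyond the scatter).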

Compound 4, negative logarithm of the antagonist equilibrium constant: 6.84
Compound 4: middle estimate off by 0.94 log units, on the low side; the whole stated range lies below it.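

In this assay the change from 4-fluorophenyl to phenyl gives a number 0.30 log units higher from compound 3 to compound 4 (within the scatter) and so does not repeat the loss seen on the core of compound 1. The step therefore does not carry over from one core to the other in these two pairs: the same change on two cores in this assay, a number 0.73 log units lower (beyond the scatter) from compound 1 to compound 2 and a number 0.30 log units higher (within the scatter) from compound 3 to compound 4, 1.03 log units apart, beyond the scatter of two such steps. This shows that a step read on the core of compound 1 cannot be assumed on the core of compound 3, but it does not show which difference between the cores matters, and two pairs give no rule for other cores.

From the compounds shown here alone, whether chloro or methoxy at the same place would follow the same split between the two cores remains open. Also open, going by these compounds, is how the step would read on a core carrying only part of the difference between these two.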